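The compounds below may be only part of what the source reports. "The series", "measured", "known", "first", "only" and "open" are said of these compounds alone.

In a functional assay on MDA-MB-231 cells (Homo sapiens) for inhibition, read by CCK-8 assay and cell counting, with a stated time of 2 days (on this read-out lower numbers stand for stronger inhibition and higher numbers for weaker inhibition), compound 1 `O=C(/C=C/c1ccco1)c1cccc(OCC2CO2)c1` gives 27800 nM, while compound 2 `O=C(/C=C/c1cccs1)c1cccc(OCC2CO2)c1` gives 15400 nM. The change between them, (thiophen-2-yl in place of furan-2-yl on a double-bonded chain carbon bound to a double-bonded chain carbon), produced a 1.8-fold lower number from compound 1 to compound 2 (0.26 log units; within the scatter). Compound 3 `O=C(/C=C/c1ccc(OCC(O)CCl)cc1)c1ccco1` belongs to a different core; how the two cores differ is not broken down here. In this assay compound 3 gives > 50000 nM, which is a limit of the assay rather than a number, namely (the limit of > 50000 nM in this assay, at which 1 of the 3 values shown sits). Compound 4 `O=C(/C=C/c1ccc(OCC(O)CCl)cc1)c1cccs1` has not yet been measured. It differs from compound 3 by thiophen-2-yl in place of furan-2-yl on a carbonyl carbon. Among the compounds with values here, this is the same kind of change as the one between compound 1 and compound 2, but not the same: there the place was on a double-bonded chain carbon bound to a double-bonded chain carbon, whereas here it is on a carbonyl carbon whose other neighbours are a double-bonded chain carbon. Because the earlier swap gave only a 1.8-fold lower number from compound 1 to compound 2 (0.26 log units; within the scatter), a similarly small step is expected, an at least 1.1-fold lower number from compound 3 to compound 4 (0.04 log units; that floor lies within the scatter). Compound 4 is therefore estimated at 45000 nM in this assay, most likely between 18000 nM and 110000 nM, with a real chance that only a limit is reported again.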

Compound 4, half-maximal inhibitory concentration: 30300 nM
Beside the measured number, compound 4's estimate is 1.5-fold (0.17 log units) above it; low and high end bracket the measured number.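

In this assay, putting thiophen-2-yl in place of furan-2-yl on a carbonyl carbon gives an at least 1.6-fold lower number from compound 3 to compound 4 (0.21 log units; that floor lies within the scatter). Set beside the same swap on the other core, this result cannot show that the change carries over unaltered, nor that the core alters its effect: the same change on two cores in this assay, a 1.8-fold lower number (0.26 log units; within the scatter) from compound 1 to compound 2 and an at least 1.6-fold lower number (0.21 log units; that floor lies within the scatter) from compound 3 to compound 4; the limit leaves it open whether they differ. From the compounds shown here alone, compound 3 stands at a limit of the assay rather than at a number, so the full size of its step stays unknown: the limit of > 50000 nM in this assay, at which 1 of the 4 values shown sits.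

The compounds shown cover only furan-2-yl and thiophen-2-yl at this place, and only two cores, so they give no view of how the swap would behave on any further core. Going by these compounds, it also stays open how the numbers in this assay would read with an amine in place of the chlorine carried by compound 3 and compound 4, or with a longer chain joining that end of the molecule to its ring.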